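Purine series: removal of the amino group at compound 3

This account rests on a few compounds, and the source may have more. Where it says the series, first, only, none or still open, it means among the compounds named here.

Measured so far:
compound 1, `ClCc1cccc(Cn2cnc3c(Cl)nc(Cl)nc32)c1`: 2390 nM
compound 2, `Nc1nc(Cl)c2ncn(Cc3ccccc3CCl)c2n1`: 4470 nM

Both numbers come from a functional assay on NCI/ADR-RES cells (Homo sapiens) for cytotoxicity, read by sulforhodamine B assay, with a stated time of 48 h; a higher number here means a weaker inhibitor of growth, a lower number a stronger inhibitor of growth. Among the measured compounds shown here, compound 2 and compound 1 give numbers that lie within the usual scatter of each other, so the series so far shows no separation beyond noise.

The next compound is compound 3, `ClCc1ccccc1Cn1cnc2c(Cl)ncnc21`. It differs from compound 2 by hydrogen in place of amino on an aromatic carbon. Compound 3 keeps the chloromethylbenzyl arm of compound 2 unchanged, so only the six-membered ring of the shared core is altered.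

For the measured compounds named here, no measured pair in this set isolates this change, so nothing here tells its size directly. With compound 2 at 4470 nM and compound 1 at 2390 nM both lying close together, the expected step of a 1.4-fold lower number from compound 2 to compound 3 (0.13 log units; within the scatter) in this assay is small, if anything towards a lower number, and not beyond the scatter. Compound 3 is expected to give about 3300 nM, with a range from 1100 nM to 10000 nM.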

Compound 3, concentration for 50% growth inhibition: 2180 nM
Compound 3: middle estimate off by 1.5-fold (0.18 log units), on the high side; measured number inside the range.
By their numbers in this assay, from the lowest: compounds 3, 1 and 2 (each within the scatter of the next, the first and the last beyond it).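

In this assay, the amino group on the aromatic carbon between two ring nitrogen atoms can be given up without loss of growth inhibition: hydrogen in its place gives a 2.1-fold lower number from compound 2 to compound 3 (0.31 log units; beyond the scatter), a modest step that only just clears the scatter. Among the compounds shown here, this is the first step confined to one place, with the chloromethylbenzyl arm unchanged, so it gives the series its first reading for this position. Nothing available accounts for the step, and its origin remains unassigned.

From the compounds shown here alone, it remains open how this position responds to other groups, such as a methoxy group or a dimethylamino group. A single pair also leaves open whether the step carries over to other arms on the shared core, such as a plain benzyl arm without the chloromethyl group.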